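The compounds below may be only part of what the source reports. "The series", "measured", "known", "first", "only" and "open" are said of these compounds alone.

- Compound 1 `CC(C)=CCC[C@H](C)c1ccc(C)c2c1OCN(CC1CCNCC1)C2`, 8100 nM
- Compound 2 `CC(C)=CCC[C@H](C)c1ccc(C)c2c1OCN(CCCCCO)C2`, 6900 nM

Both values come from a functional assay on MCF7 cells (Homo sapiens) for inhibition, read by MTT assay, with a stated time of 72 h; a higher number here means a weaker inhibitor, a lower number a stronger inhibitor. With only these two numbers, compound 2 stands level with compound 1. Compound 3 `CC(C)=CCC[C@H](C)c1ccc(C)c2c1OCN(CCCCC(=O)O)C2` changes compound 2 at one place: carboxy in place of hydroxymethyl on a saturated chain carbon, four bonds along the chain from an amine nitrogen in a ring. That is carboxy in place of hydroxymethyl, four bonds along the chain from an amine nitrogen in a ring. Among the measured compounds shown here, no measured step covers this exact swap. The nearest evidence is a change of 4-hydroxybutyl for piperidin-4-yl, which gave a 1.2-fold lower number from compound 1 to compound 2 (0.07 log units; within the scatter), so a small shift is expected here too, leaning slightly upward, and nothing clearly beyond the scatter: the expected step is a 1.3-fold higher number from compound 2 to compound 3 (0.12 log units; within the scatter). For compound 3 the estimated value is 9000 nM, with an expected range of 4000 nM to 25000 nM.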

Compound 3, half-maximal inhibitory concentration: > 20000 nM
Compound 3 gave a limit, no number (the forecaster's own chance of this, stated with the estimate: 15%); at least 2.2-fold (0.34 log units) between middle value and limit.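

This position is not indifferent to what ends the chain: carboxy in place of hydroxymethyl gives an at least 2.8-fold higher number from compound 2 to compound 3 (0.46 log units; beyond the scatter), whereas the earlier swap stayed within the scatter. The 3-carboxypropyl group in place of piperidin-4-yl likewise gives an at least 2.4-fold higher number from compound 1 to compound 3 (0.39 log units; beyond the scatter). Compound 3 sits at a limit of this assay, not at a number: the limit of > 20000 nM in this assay, at which 1 of the 3 values shown sits.

The compounds shown leave open whether a methyl ester or an amide in place of carboxy would return to the level of compound 2. A longer chain ending in carboxy also remains an open case.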